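The source may hold more compounds than are shown below. What is called first, only, known or untested is meant among the compounds shown, and "the series" means these compounds.

Of the compounds shown here, two have been measured so far in a functional assay on HT-29 cells (Homo sapiens) for inhibition, read by MTT assay, with a stated time of 48 h; a higher number here means a weaker inhibitor, a lower number a stronger inhibitor. Compound 1 `COc1cc(-c2nnc(S)n2-c2ccc(N(C)C)cc2)cc(OC)c1OC`, with hydrogen on the sulfur, reads > 60000 nM, and this value is a limit of the assay. Among the measured compounds shown here, compound 2 `COc1cc(-c2nnc(SCc3ccc(C)cc3)n2-c2ccc(N(C)C)cc2)cc(OC)c1OC`, with 4-methylbenzyl on that sulfur, gives 27500 nM, the only actual number available. Compound 3 `COc1ccc(C(=O)CSc2nnc(-c3cc(OC)c(OC)c(OC)c3)n2-c2ccc(N(C)C)cc2)cc1` has not yet been measured. It departs from compound 2 by (4-methoxyphenyl)carbonyl in place of 4-methylphenyl on a saturated chain carbon bound to a sulfur, with (4-methoxyphenyl)carbonyl in place of 4-methylphenyl on a saturated chain carbon bound to a sulfur. For the measured compounds named here, only one measured step bears on this change: an at least 2.1-fold lower number from compound 1 to compound 2 (0.33 log units; beyond the scatter). From the compounds shown here alone, that step lies beyond the scatter, but its full size stays open, as the limit of > 60000 nM in this assay, at which 1 of the 2 values shown sits, marks. It also replaces hydrogen, whereas compound 3 exchanges one substituent on the sulfur chain for another, so it sets no size for the new change. No step beyond the scatter is therefore expected in this assay, in either direction. The estimated value for compound 3 is 25000 nM, with an expected range from 8000 nM to 60000 nM. This estimate amounts to an expected 1.1-fold lower number from compound 2 to compound 3 (0.04 log units; within the scatter).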

Compound 3, half-maximal inhibitory concentration: 64000 nM
Estimate against measurement, compound 3: 2.6-fold (0.41 log units) below; the measured number lies above the stated range.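

On a saturated chain carbon bound to a sulfur, this assay now gives the first size for exchanging one substituent for another: (4-methoxyphenyl)carbonyl in place of 4-methylphenyl gives a 2.3-fold higher number from compound 2 to compound 3 (0.37 log units; beyond the scatter). The earlier compounds shown here showed only what followed when a group replaced hydrogen on the sulfur, whereas this step shows that the choice of substituent on the chain also changes the reading, here towards weaker inhibition and beyond the scatter. Compound 1 stands at a limit of the assay, so the one step that starts from it here cannot be read: the limit of > 60000 nM in this assay, at which 1 of the 3 values shown sits.

The exchange brings in a carbonyl and a methoxy in place of a methyl together, so the compounds shown do not tell which of these parts carries the step. From the compounds shown here alone, a 4-methoxybenzyl or a (4-methylphenyl)carbonyl on the same chain carbon would separate the two, and how a carboxylic acid or an amine at this place would read remains open as well.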